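A few compounds are considered here, and "the series" means these few. Any claim that something is new, unique, unknown or untested is made for them only; others in the source may bear on it.

Working notes on the series. In a toxicity assay on cells (Macrophage, Mus musculus, strain BALB/c) for cytotoxicity, read by MTT assay (a lower number here means a stronger inhibitor, a higher number a weaker inhibitor), compound 1 `COc1cc(O)cc(O)c1C(=O)/C=C/c1ccc(C(F)(F)F)cc1` gives 17100 nM and compound 3 `COc1cc(O)cc(O)c1C(=O)/C=C/c1ccccc1F` gives 16000 nM. Compound 2 `C=CCOc1cc(OC)c(C(=O)/C=C/c2ccccc2Br)c(OCC=C)c1` gives 5400 nM, the lowest of the three numbers, with the numbers of compound 3 and compound 1 both standing beyond the scatter above it. Compound 4 `C=CCOc1cc(OC)c(C(=O)/C=C/c2ccc(Cl)cc2)c(OCC=C)c1` is not yet measured in this assay. How it differs from compound 2: 4-chlorophenyl in place of 2-bromophenyl on a double-bonded chain carbon bound to a double-bonded chain carbon. Among the measured compounds shown here, no measured pair shows this change, so the expectation rests on compound 2 alone. The expected step of a 1.4-fold higher number from compound 2 to compound 4 (0.14 log units; within the scatter) is small, toward a somewhat higher number, and may fall within the scatter. For compound 4 the estimate in this assay is 7500 nM, with a range from 2700 nM to 21000 nM.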

Compound 4, half-maximal inhibitory concentration: 13000 nM
Compound 4: middle estimate off by 1.7-fold (0.24 log units), on the low side; the measured number falls inside the stated range.
By their numbers in this assay, from the lowest: compound 2; then compounds 4, 3 and 1 (each within the scatter of the next).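

In this assay, 4-chlorophenyl in place of 2-bromophenyl on a double-bonded chain carbon bound to a double-bonded chain carbon gives a 2.4-fold higher number from compound 2 to compound 4 (0.38 log units; beyond the scatter), so the number responds to the group held at this place. Among the compounds shown here, this is the first one-place pair, and its step lies beyond the scatter, but the halogen and its place on the phenyl change together. Nothing at hand accounts for the step. On these data alone, whether 2-chlorophenyl or 4-bromophenyl would separate these two changes remains open, as does the effect of an amine or a carboxylic acid on the phenyl.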